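The source may report more compounds than this note shows. Statements on the series, on what has been measured and on what is new or still open speak of the compounds shown alone.

For the measured compounds named here, compound 2 `Cc1ccc(NC(=O)Nc2cc(C(C)(C)C)nn2-c2ccccc2)cc1` stands highest of the two compounds measured so far: in an assay on isolated protein for inhibition of STE20-like serine/threonine-protein kinase (Homo sapiens), read by thermal shift assay, tested at 10 uM (on this read-out higher numbers stand for stronger stabilisation of the target against heat and lower numbers for weaker stabilisation of the target), compound 2 gives 4.6 degrees C, while compound 1 `Cc1cc(C)cc(NC(=O)Nc2cc(C(C)(C)C)nn2-c2ccccc2)c1` gives 2.4 degrees C. The one step between them, a number 2.2 degrees C higher from compound 1 to compound 2 (beyond the scatter), is the only measured comparison available. Compound 3 `CC(C)(C)c1cc(NC(=O)Nc2cc(F)cc(F)c2)n(-c2ccccc2)n1` is the next compound in this series and differs from compound 2 by 3,5-difluorophenyl in place of 4-methylphenyl on an amide-type nitrogen. Going by the values given here, no measured step matches this change directly; the step from compound 1 to compound 2 bears on it only in that compound 3, like compound 1, carries a 3,5-disubstituted phenyl ring rather than the 4-methylphenyl of compound 2, and that step was modest. Compound 3 is therefore expected to fall somewhat below compound 2 in this assay, by a step of about a number 1.4 degrees C lower from compound 2 to compound 3 (beyond the scatter), though a result within the scatter of compound 2 would not be surprising. The estimate for compound 3 in this assay is 3.2 degrees C, with a range from 1.5 degrees C to 5 degrees C.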

Compound 3, shift of the target's melting temperature: 3 degrees C
The estimate for compound 3 lay 0.20 degrees C above the measured number; measured number inside the range.
By their numbers in this assay, from the lowest: compounds 1 and 3 (each within the scatter of the next); then compound 2.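

In this assay, a number 1.6 degrees C lower from compound 2 to compound 3 (beyond the scatter), so a second 3,5-disubstituted phenyl on the amide-type nitrogen also stands lower than the 4-methylphenyl of compound 2, this time with fluorine on the ring in place of methyl. The two 3,5-disubstituted rings themselves do not separate, as a number 0.60 degrees C higher from compound 1 to compound 3 (within the scatter), which means that exchanging 3,5-dimethylphenyl for 3,5-difluorophenyl leaves no readable difference at this position. Among these three compounds, compound 2 stands above both others and none goes against that order, but no measurement at hand offers an explanation for it.

The compounds shown leave open whether the gap follows from the 4-methylphenyl itself or from the 3,5-disubstitution, a question that an unsubstituted phenyl or a single chlorine or methoxy group on the ring could help to answer. They also leave open whether the same order would hold with a pyridine ring at this nitrogen, or with a group other than the tert-butyl on the shared core.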